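Fluoro substitution on the aryl ring of thiopurine analogues

The source may report more compounds than this note shows. Statements on the series, on what has been measured and on what is new or still open speak of the compounds shown alone.

Compound 1 `c1ccc(Sc2ncnc3[nH]cnc23)cc1` was tested in an assay on isolated protein for inhibition of Ca2+/calmodulin-dependent protein kinase II (CaM kinase II) (Rattus norvegicus), tested at 30 uM (a higher number here means more inhibition at the concentration tested (going by the name of the read-out), a lower number less inhibition), and in that setting compound 1 gives 0%. Compound 2 `Fc1ccc(Sc2ncnc3[nH]cnc23)cc1` carries the change (fluoro in place of hydrogen on an aromatic carbon), and in this assay compound 2 gives 0%. The step of no change at the digits printed from compound 1 to compound 2 (within the scatter) therefore shows no movement. Compound 3 `Cn1cnc2c(SCc3ccccc3)ncnc21` has a core that differs from the core of compound 1 in a way that is not broken down here; in this assay compound 3 gives 0%, level with compound 1 and compound 2.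

Compound 4 `Cn1cnc2c(SCc3ccc(F)cc3)ncnc21` is not yet measured. It differs from compound 3 by fluoro in place of hydrogen on an aromatic carbon, the same change that separates compound 1 from compound 2. Because no change at the digits printed from compound 1 to compound 2 (within the scatter) was flat and because compound 3 already sits at 0%, the step of no change at the digits printed from compound 3 to compound 4 (within the scatter) is expected to be flat as well. On that basis compound 4 is estimated to give 0% in this assay, with a range from -5% to 10%.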

Compound 4, a percentage reported as inhibition, at one concentration (the size of the read-out at that concentration, not a potency): 5%
Beside the measured number, compound 4's estimate is 5 percentage points below it; measured number inside the range.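

On the core of compound 3, fluoro in place of hydrogen on an aromatic carbon gives a number 5 percentage points higher from compound 3 to compound 4 (within the scatter) in this assay. Set beside the same change on the core of compound 1, the two steps do not differ beyond the scatter, so in this small set the change behaves alike on both cores: the same change on two cores in this assay, no change at the digits printed (within the scatter) from compound 1 to compound 2 and a number 5 percentage points higher (within the scatter) from compound 3 to compound 4, 5 percentage points apart, within the scatter of two such steps. This does not show that the change would carry over alike on a core with clear inhibition, for compound 3 gives 0% and compound 4 gives 5%, and a flat step at such low values says little about how the change acts where there is more inhibition to lose or gain.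

The compounds shown leave open whether another group on the aryl ring, such as an amine or a carboxylic acid, or a longer chain on the sulfur, would produce clear inhibition on either core. Among the compounds shown here, they also give no potency for any compound, as the read-out is a percentage at one concentration.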